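The compounds below may be only part of what the source reports. "The series", "measured", "known", "first", "only" and "open" are said of these compounds alone.

Within the data shown here, compound 1 `CCCCCCCCCCCCCCC[C@@H](O)[C@@H](N)[C@@H](C)O` is the weaker of the two compounds measured so far in a functional assay on WiDr cells (Homo sapiens) for antiproliferative activity, read by sulforhodamine B assay, with a stated time of 48 h (a higher number here means a weaker inhibitor of growth, a lower number a stronger inhibitor of growth), where compound 1 gives 18000 nM. Compound 2 `CCCCCCCCC[C@@H](O)[C@@H](N)[C@@H](C)O` shortens the chain and gives 14000 nM, a change of a 1.3-fold lower number from compound 1 to compound 2 (0.11 log units; within the scatter). Compound 3 `CCCCCCCCCCCCCCC[C@@H](O)[C@@H](N)[C@@H](C)CC` is not yet measured. It differs from compound 1 by ethyl in place of hydroxy on a saturated chain carbon bound to two saturated chain carbons. Among the measured compounds shown here, no measured step touches this position: the only step on record, that from compound 1 to compound 2, changes the long chain alone and stays within the scatter, so it says nothing about replacing the hydroxy group with ethyl. The expected step from compound 1 to compound 3 is therefore taken as no change at the digits printed from compound 1 to compound 3 (within the scatter), with the direction left open and a wide range. Compound 3 is estimated to give 18000 nM, between 5000 nM and 60000 nM.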

Compound 3, concentration for 50% growth inhibition: 13000 nM
For compound 3 the middle estimate is 1.4-fold (0.14 log units) above the measured one, and the stated range covers the measured number.
By their numbers in this assay, from the lowest: compounds 3, 2 and 1 (each within the scatter of the next).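

Among these compounds, this is the first reading at the saturated chain carbon bound to two saturated chain carbons, since the earlier step changed only the long chain. In this assay the step reads a 1.4-fold lower number from compound 1 to compound 3 (0.14 log units; within the scatter): ethyl, which counts no hydrogen-bond donor or acceptor, stands in place of hydroxy, which counts one of each, and the two compounds cannot be told apart. The hydroxy group at this place is therefore not needed to keep the reading of compound 1 in this assay, and nothing available here gives a reason for this result.

The compounds shown leave open whether an amine, a carboxylic acid or a longer chain at this place would read the same way. They also leave open whether ethyl in place of hydroxy would give the same reading on the shorter chain of compound 2.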